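The compounds below may be only part of what the source reports. "The series", "measured", "known", "first", "only" and "open" are said of these compounds alone.

In an ADME assay on HEK-293T cells (Homo sapiens) for inhibition, read by CCK-8 assay, with a stated time of 48 h, tested at 20 uM (on this read-out higher numbers stand for more inhibition of growth at the one concentration tested and lower numbers for less inhibition of growth), compound 2 (`N#C/C(=C\c1ccccc1OS(=O)(=O)c1ccc([N+](=O)[O-])cc1)C(=O)Nc1nnc(Cc2ccc(F)cc2)s1`) gives 8%, within the scatter of compound 1 (`N#C/C(=C\c1ccccc1OS(=O)(=O)c1ccc(F)cc1)C(=O)Nc1nnc(Cc2cccc3ccccc23)s1`) at 15%. Compound 3 (`N#C/C(=C\c1ccccc1OS(=O)(=O)c1ccc(F)cc1)C(=O)Nc1nnc(Cc2ccc(F)cc2)s1`) differs from compound 2 at one place: fluoro in place of nitro on an aromatic carbon, with fluoro in place of nitro on an aromatic carbon. The same (4-fluorophenyl)sulfonyl already occurs in compound 1, although its other substituent differs, so that value offers only a loose guide. The expected step of a number 2 percentage points higher from compound 2 to compound 3 (within the scatter) in this assay is none beyond the scatter. For compound 3 the estimated value is 10%, with an expected range of 2% to 22%.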

Compound 3, percent growth inhibition at one concentration: "not toxic" (no number reported)
Compound 3 has no reported number here; no gap can be computed for the estimate.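

In this assay, going by these compounds alone, compound 3 gives "not toxic" (no number reported), and no step from compound 2 to compound 3 can be read. The compounds shown leave open how fluoro in place of nitro shifts growth inhibition, and no evidence bears on this result.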